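A few compounds are considered here, and "the series" means these few. Any claim that something is new, unique, unknown or untested is made for them only; others in the source may bear on it.

Measured so far:
compound 1 `O=C(C1C(=O)N(O)C(=O)c2ccccc21)N1CCCCC1`: 120000 nM
compound 2 `CCCCCNC(=O)C1C(=O)N(O)C(=O)c2ccccc21`: 130000 nM
compound 3 `CC(C)(C)NC(=O)C1C(=O)N(O)C(=O)c2ccccc21`: 142000 nM

All three compounds were tested in an ADME assay on MT4 cells (Homo sapiens) for cytotoxicity, read by MTT assay; on this read-out higher numbers stand for lower toxicity in this test and lower numbers for higher toxicity in this test. Compound 3, at 142000 nM, does not stand apart from the other two, and its values sit within the scatter of both. The steps that reach it are a 1.1-fold higher number from compound 2 to compound 3 (0.04 log units; within the scatter) and a 1.2-fold higher number from compound 1 to compound 3 (0.07 log units; within the scatter). The remaining step is a 1.1-fold higher number from compound 1 to compound 2 (0.03 log units; within the scatter).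

Compound 4 `O=C(NC1CCCC1)C1C(=O)N(O)C(=O)c2ccccc21` has cyclopentyl in place of tert-butyl on an amide-type nitrogen. Among the measured compounds shown here, no measured compound carries cyclopentyl, so the evidence is indirect. The closest comparison is the swap of pentyl for tert-butyl at the same nitrogen, which gave a 1.1-fold higher number from compound 2 to compound 3 (0.04 log units; within the scatter). All three measured steps stayed within the scatter, so no change beyond the scatter is expected in this assay. The expected step is a 1.1-fold lower number from compound 3 to compound 4 (0.04 log units; within the scatter). Compound 4 is estimated at 130000 nM, with an expected range from 75000 nM to 210000 nM.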

Compound 4, half-maximal cytotoxic concentration: > 250000 nM
Compound 4 was reported as a limit; the forecaster's own chance of this, stated with the estimate: 10%; at least 1.9-fold (0.28 log units) between middle value and limit.
By their numbers in this assay, from the lowest: compounds 1, 2 and 3 (each within the scatter of the next). At a limit, above all of these: compound 4.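

In this assay compound 4 is reported as a limit and not as a number: the limit of > 250000 nM in this assay, at which 1 of the 4 values shown sits. With cyclopentylamino on the carbonyl carbon, this series shows its first step beyond the scatter, an at least 2.0-fold higher number from compound 1 to compound 4 (0.31 log units; beyond the scatter), so this position can carry a change that lowers toxicity in this test relative to the piperidin-1-yl amide. Against the pentyl and tert-butyl amides the floors still lie within the scatter, an at least 1.9-fold higher number from compound 2 to compound 4 (0.28 log units; that floor lies within the scatter) and an at least 1.7-fold higher number from compound 3 to compound 4 (0.24 log units; that floor lies within the scatter), so the real size of these two steps cannot be read, and a true difference from those groups is possible but not shown.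

From the compounds shown here alone, how far the true value of compound 4 lies past its limit remains open. So does whether cyclopropyl or cyclohexyl on the same nitrogen, or an amine or a carboxylic acid on the cyclopentyl ring, would behave in the same way.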